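Removing the Carbamate from a Bis-aziridinyl Quinone

The source may hold more compounds than are shown below. What is called first, only, known or untested is meant among the compounds shown, and "the series" means these compounds.

Measured compounds:
Compound 1, `COCCC1=C(N2CC2)C(=O)C(CCOC)=C(N2CC2)C1=O`, gives 5.69.
Compound 2, `CCC1=C(N2CC2)C(=O)C(CCOC(N)=O)=C(N2CC2)C1=O`, gives 6.25.
Compound 3, `CCCC1=C(N2CC2)C(=O)C(CCOC(N)=O)=C(N2CC2)C1=O`, gives 5.68.

All three numbers come from a functional assay on L1210 cells (Mus musculus), with a stated time of 12 days; on this read-out lower numbers stand for lower potency and higher numbers for higher potency (the scale is a negative logarithm). Among them compound 2 stands highest; compound 1 lies a number 0.57 log units lower from compound 2 to compound 3 (beyond the scatter) is the only measured step, and compound 1 sits a similar distance below compound 2, both gaps beyond the scatter.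

The step of interest goes from compound 2 to compound 4, `CCC1=C(N2CC2)C(=O)C(CC)=C(N2CC2)C1=O`. The change is hydrogen in place of carbamoyloxy on a saturated chain carbon, two bonds along the chain from a double-bonded ring carbon.

Among the compounds with values here, no measured pair shows this exact change, so nothing bears on it directly. Within the data shown here, the one measured step, a number 0.57 log units lower from compound 2 to compound 3 (beyond the scatter), concerns a different change at the same place on the chain, and it shows that alteration at that position is not indifferent to this read-out. Compound 1, which also lacks the carbamoyloxy group, gives 5.69, but it differs from compound 2 in more than one place, so it only hints at the direction.

On this basis compound 4 is expected to fall below compound 2, with an estimated step of a number 0.55 log units lower from compound 2 to compound 4 (beyond the scatter). Compound 4 is therefore estimated at 5.7, with a range from 5.2 to 6.3.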

Compound 4, logarithm of the reciprocal of the active concentration, log(1/C): 5.46
Compound 4: the middle estimate sits 0.24 log units above what was measured, within the range that was stated.
By their numbers in this assay, from the lowest: compounds 4, 3 and 1 (each within the scatter of the next); then compound 2.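

Within the data shown here, with a number 0.79 log units lower from compound 2 to compound 4 (beyond the scatter), the loss of carbamoyloxy is now a measured single change in this assay, where the earlier compounds offered only the hint from compound 1, which differs from compound 2 in more than one place. Replacing 2-(carbamoyloxy)ethyl with ethyl, with no other alteration to the shared core, is enough to take the number down, so this group's presence on the chain matters to the read-out in the setting of compound 2. Nothing measured here explains the drop, and no independent data on the compounds bear on it.

The compounds shown leave open whether a hydroxyl group, an amine or a carboxylic acid in place of carbamoyloxy on this chain would keep the number near that of compound 2, at 6.25, or bring it down as hydrogen does. They also leave open whether removing carbamoyloxy has a step of similar size when the propyl chain of compound 3 stands in place of the ethyl chain of compound 2.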